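The compounds below may be only part of what the source reports. "The series", "measured", "known", "first", "only" and "open" are said of these compounds alone.

Working notes on the series. The measured compounds are compound 1 `COc1cc(/C(=N/OC(C)=O)c2ccc3c(ccn3C)c2)cc(OC)c1OC`, compound 2 `COc1cc(/C(=N/N)c2ccc3c(ccn3C)c2)cc(OC)c1OC` and compound 3 `COc1cc(/C(=N/NC(C)=O)c2ccc3c(ccn3C)c2)cc(OC)c1OC`; the unmeasured compound 4 `CN/N=C(/c1cc(OC)c(OC)c(OC)c1)c1ccc2c(ccn2C)c1` belongs to the same set. In a functional assay on HL-60 cells (Homo sapiens) for cytotoxicity, read by XTT assay, with a stated time of 72 h (a lower number here means a stronger inhibitor, a higher number a weaker inhibitor), compound 1 reaches only a limit of the assay, > 10000 nM. Compound 2 likewise gives only a limit in this assay, > 10000 nM. Compound 3 stands at a limit too, > 1000 nM in this assay, so no number places it against the others. The three steps measured so far, a step that the two limits leave unreadable from compound 1 to compound 2, a step that the two limits leave unreadable from compound 1 to compound 3 and a step that the two limits leave unreadable from compound 2 to compound 3, all run between limits and cannot be read in size or direction; they show only that every variation at the double-bonded nitrogen so far has left the compounds at the limit of > 1000 nM in this assay, at which 1 of the 3 values shown sits, or (the limit of > 10000 nM in this assay, at which 2 of the 3 values shown sit). The change to compound 4 is methyl in place of acetyl on an amine nitrogen. Among the compounds with values here, none of the measured steps bears readably on this change, and the nearest measured compound, compound 3, sits at a limit in this assay with > 1000 nM. Compound 4 is expected to stay weak in this assay, most likely again reported as a limit, with an estimate of 15000 nM and a range from 3000 nM to 60000 nM. The step that the limit leaves unreadable from compound 3 to compound 4 is accordingly expected to lie within the scatter, in no clear direction.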

Compound 4, half-maximal inhibitory concentration: > 1000 nM
Compound 4: only a limit was reported; the forecaster's own chance of this, stated with the estimate: 75%; the middle value is on the limit's open side.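

In this assay compound 4 gives only a limit, > 1000 nM. Its steps to compound 1, compound 2 and compound 3 all run between limits, so none of them can be read in size or direction. The compounds shown leave open what actual value any of the four has in this assay, and whether the group on the double-bonded nitrogen changes it at all.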